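A few compounds are considered here, and "the series" means these few. Any claim that something is new, unique, unknown or untested is made for them only; others in the source may bear on it.

Within the data shown here, in a functional assay on P388 cells (Mus musculus) for cytotoxicity (a higher number here means a weaker inhibitor, a lower number a stronger inhibitor), compound 1 `Cc1cc(-c2c(F)cc3c(=O)ccn(C4CC4)c3c2F)cc(C)n1` gives 15000 nM and compound 2 `Cc1cc(-c2c(F)cc3c(=O)c(Cc4ccccc4)cn(C4CC4)c3c2F)cc(C)n1` gives 7300 nM, the lower of the two numbers so far. Compound 3 `Cc1cc(-c2c(F)cc3c(=O)c(Cc4ccc(O)cc4O)cn(C4CC4)c3c2F)cc(C)n1` differs from compound 2 as follows: 2,4-dihydroxyphenyl in place of phenyl on a saturated chain carbon bound to an aromatic carbon. That is 2,4-dihydroxyphenyl in place of phenyl on a saturated chain carbon bound to an aromatic carbon. Among the measured compounds shown here, only one measured step bears on this, the modest 2.1-fold lower number from compound 1 to compound 2 (0.31 log units; beyond the scatter), and no measured compound carries a substituted phenyl, so the direction remains uncertain. A similarly modest move to a lower number is expected, estimated as a 2.1-fold lower number from compound 2 to compound 3 (0.32 log units; beyond the scatter). For compound 3 the estimated value is 3500 nM, with an expected range of 700 nM to 12000 nM.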

Compound 3, half-maximal inhibitory concentration: 210 nM
Compound 3: middle estimate off by 17-fold (1.22 log units), on the high side; the whole stated range lies above it.
By their numbers in this assay, from the lowest: compound 3; then compound 2; then compound 1.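

In this assay this position responds far more to substitution on the phenyl than to the benzyl itself: 2,4-dihydroxyphenyl in place of phenyl gives a 35-fold lower number from compound 2 to compound 3 (1.54 log units; beyond the scatter) in this series, while benzyl in place of hydrogen gave only a 2.1-fold lower number from compound 1 to compound 2 (0.31 log units; beyond the scatter) here. The whole 2,4-dihydroxybenzyl group brings a 71-fold lower number from compound 1 to compound 3 (1.85 log units; beyond the scatter) and most of that comes with the two hydroxyl groups. Still open, as far as these compounds go, is whether a single hydroxyl group would carry the step, and whether methoxy groups or an amine on the phenyl would keep it. No measurement on hand accounts for the size of this step.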